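Amide to urea on a shared pyrazole-bearing core

The compounds below may be only part of what the source reports. "The series", "measured", "known", "first", "only" and "open" are said of these compounds alone.

Measured compounds:
Compound 1 `COc1cc(-c2nn(-c3cccc(NC(=O)c4cccc(C(F)(F)F)c4)c3)cc2-c2ccncc2)ccc1Cl` gives 1660 nM in a functional assay on NCI-H226 cells (Homo sapiens) for inhibition, read by sulforhodamine B assay, with a stated time of 48 h; a higher number here means a weaker inhibitor of growth, a lower number a stronger inhibitor of growth.
Compound 2 `O=C(Nc1cccc(-n2cc(-c3ccncc3)c(-c3ccc(Cl)c(O)c3)n2)c1)Nc1cc(C(F)(F)F)cc(C(F)(F)F)c1` gives 1240 nM in this assay.
Compound 3 `O=C(Nc1cccc(-n2cc(-c3ccncc3)c(-c3ccc(Cl)c(O)c3)n2)c1)Nc1ccc(Cl)c(C(F)(F)F)c1` gives 1350 nM in this assay.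

The three measured compounds sit close together. Compound 1 carries a methoxy group on its chlorophenyl ring and an amide to a 3-(trifluoromethyl)phenyl group; its number lies within the usual scatter of both compound 2 and compound 3, so nothing separates the three. For the measured compounds named here, compound 2 and compound 3 are ureas and carry a hydroxy group in place of the methoxy group, differing from compound 1 in more than one place, so no single step between them and compound 1 can be read from the values.

Compound 4 `COc1cc(-c2nn(-c3cccc(NC(=O)Nc4ccc(Cl)c(Cl)c4)c3)cc2-c2ccncc2)ccc1Cl` keeps the methoxy group of compound 1 and changes only the amide end: (3,4-dichlorophenyl)amino in place of 3-(trifluoromethyl)phenyl on a carbonyl carbon. The change turns the amide into a urea, as in compound 2 and compound 3, whose values in this assay do not stand apart from compound 1.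

Compound 4 is therefore expected to stay within the scatter of compound 1, with a step of a 1.3-fold lower number from compound 1 to compound 4 (0.11 log units; within the scatter) that is estimated to carry no direction beyond the noise. The estimate for compound 4 is 1300 nM, with a range from 600 nM to 2800 nM.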

Compound 4, concentration for 50% growth inhibition: 1350 nM
The estimate for compound 4 lay 1.0-fold (0.02 log units) below the measured number; the range from low to high includes it.
By their numbers in this assay, from the lowest: compounds 2, 3, 4 and 1 (each within the scatter of the next).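

In this assay, for the compounds shown here, the step at this carbonyl carbon is the first that can be read on its own: with the methoxy group held fixed, (3,4-dichlorophenyl)amino in place of 3-(trifluoromethyl)phenyl gives a 1.2-fold lower number from compound 1 to compound 4 (0.09 log units; within the scatter). The earlier compounds shown here could not show this, as the ureas compound 2 and compound 3 also carry a hydroxy group and differ from compound 1 in more than one place. Here, a urea in place of the amide, with a different aromatic ring on it and one more hydrogen-bond donor, leaves the number within the scatter, and no measurement offered here explains that outcome.

What stays open is how the two parts of this change contribute, as the new nitrogen and the change of ring substituents arrive together in a single step and the compounds shown do not separate them. Also open, as far as these compounds go, is whether this carbonyl carbon would keep the number within the scatter if it carried something other than a substituted phenyl or phenylamino group, such as a saturated amine like morpholine or a chain ending in a carboxylic acid.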